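Removing the chloro from the fluorinated anilide

This account rests on a few compounds, and the source may have more. Where it says the series, first, only, none or still open, it means among the compounds named here.

Compound 1 `O=C(Nc1ccc(Oc2ccnc3[nH]ccc23)cc1)c1nn(-c2ccc(Cl)cc2)ccc1=O` gives 25100 nM in a functional assay on A549 cells (Homo sapiens) for cytotoxicity, read by MTT assay, with a stated time of 72 h; a higher number here means a weaker inhibitor, a lower number a stronger inhibitor. Compound 2 `O=C(Nc1ccc(Oc2ccnc3[nH]ccc23)cc1)c1nn(-c2ccc(Cl)c(F)c2)ccc1=O` gives 2580 nM in this assay. For compound 3 `O=C(Nc1ccc(Oc2ccnc3[nH]ccc23)c(F)c1)c1nn(-c2ccc(Cl)cc2)ccc1=O` the this assay reports only a limit, > 60000 nM, so compound 3 stands at the limit of > 60000 nM in this assay, at which 1 of the 3 values shown sits, and no number is known for it.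

The two measured steps both add a fluoro: on the aryl carried by the ring nitrogen the number fell a 9.7-fold lower number from compound 1 to compound 2 (0.99 log units; beyond the scatter), on the anilide ring it rose an at least 2.3-fold higher number from compound 1 to compound 3 (0.37 log units; beyond the scatter). For the measured compounds named here, neither touches the chloro, so no measured step covers the present change, hydrogen in place of chloro on an aromatic carbon at its place: on an aromatic carbon of a six-membered aromatic ring of carbon only, para to a large group; cut one bond further out, 4-chlorophenyl to phenyl.

Compound 4 `O=C(Nc1ccc(Oc2ccnc3[nH]ccc23)c(F)c1)c1nn(-c2ccccc2)ccc1=O` is therefore expected to stay near the limit. The step expected is a step that the limit leaves unreadable from compound 3 to compound 4, within the scatter. The estimate for compound 4 in this assay is 80000 nM, between 30000 nM and 200000 nM, most likely reported again as a limit.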

Compound 4, half-maximal inhibitory concentration: 56800 nM
The estimate for compound 4 lay 1.4-fold (0.15 log units) above the measured number, and the stated range covers the measured number.
By their numbers in this assay, from the lowest: compound 2; then compound 1; then compound 4. At a limit, above all of these: compound 3.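

In this assay, for the compounds shown here, compound 4 gives 56800 nM, the first actual number for the fluorinated anilide. Taking off the chloro, 4-chlorophenyl to phenyl, gives an at least 1.0-fold lower number from compound 3 to compound 4 (0.02 log units; that floor lies within the scatter), so nothing here shows that the chloro at this place is needed for the cytotoxicity that remains on this anilide. Compound 3 is held only as a limit, and the true size of the step cannot be read because of it: the limit of > 60000 nM in this assay, at which 1 of the 4 values shown sits.

The compounds shown leave open whether losing the chloro reads the same on the anilide without the fluoro, and whether the fluoro that gave a 9.7-fold lower number from compound 1 to compound 2 (0.99 log units; beyond the scatter) would act alike on the phenyl of compound 4. They also leave open what an amine or a methoxy at this place on the phenyl would do.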